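Benzyl halogen changes in a cytotoxicity series

A few compounds are considered here, and "the series" means these few. Any claim that something is new, unique, unknown or untested is made for them only; others in the source may bear on it.

Measured compounds in a functional assay on A549 cells (Homo sapiens) for cytotoxicity, read by MTT assay, with a stated time of 48 h; on this read-out higher numbers stand for weaker inhibition and lower numbers for stronger inhibition:
compound 1 `O=c1ccoc2cc(OCc3cn(Cc4cccc(F)c4)nn3)ccc12` gives > 100000 nM, a limit of the assay.
compound 2 `O=c1ccoc2cc(OCc3cn(Cc4cccc(Cl)c4)nn3)ccc12` gives 13700 nM.
compound 3 `O=c1ccoc2cc(OCc3cn(Cc4ccccc4Cl)nn3)ccc12` gives > 100000 nM, a limit of the assay.

Compound 3 sits at the limit of > 100000 nM in this assay, at which 2 of the 3 values shown sit. Among the measured compounds shown here, compound 2 is the only one with a read number. The change fluoro in place of chloro on an aromatic carbon produces an at least 7.2-fold higher number from compound 2 to compound 1 (0.86 log units; beyond the scatter). Moving the group by 2-chlorophenyl in place of 3-chlorophenyl on a saturated chain carbon bound to an aromatic nitrogen produces an at least 7.2-fold higher number from compound 2 to compound 3 (0.86 log units; beyond the scatter). Between compound 1 and compound 3 the two limits give a step that the two limits leave unreadable from compound 1 to compound 3.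

Compound 4 `O=c1ccoc2cc(OCc3cn(Cc4ccccc4F)nn3)ccc12` is not yet measured. It differs from compound 3 by fluoro in place of chloro on an aromatic carbon. This is the same kind of change as in compound 1, but at a different place: meta to a large group there, ortho to a large group here. Given that compound 3 already rests at a limit, and that the related change gave an at least 7.2-fold higher number from compound 2 to compound 1 (0.86 log units; beyond the scatter), compound 4 is expected to show a step that the limit leaves unreadable from compound 3 to compound 4, most likely again only a limit. Compound 4 is estimated at 150000 nM in this assay, with a range of 50000 nM to 500000 nM.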

Compound 4, half-maximal inhibitory concentration: 10800 nM
Compound 4: the middle estimate sits 14-fold (1.14 log units) above what was measured; the measured number lies below the stated range.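

In this assay, the exchange of chloro for fluoro does not carry from one core to the other, as the two steps point in opposite directions: the same change on two cores in this assay, an at least 7.2-fold higher number (0.86 log units; beyond the scatter) from compound 2 to compound 1 and an at least 9.2-fold lower number (0.96 log units; beyond the scatter) from compound 3 to compound 4, at least 67-fold (1.82 log units) apart, beyond the scatter of two such steps. The step of an at least 9.2-fold lower number from compound 3 to compound 4 (0.96 log units; beyond the scatter) goes with an at least 9.2-fold lower number from compound 1 to compound 4 (0.96 log units; beyond the scatter), while a 1.3-fold lower number from compound 2 to compound 4 (0.10 log units; within the scatter) stays within the scatter, so among these four compounds the outcome of a halogen change depends on where the halogen sits. This does not give the true size of either halogen step or a reason for the reversal, and with so few compounds it is no general rule, since each of the two halogen steps rests on a limit rather than a read number: the limit of > 100000 nM in this assay, at which 2 of the 4 values shown sit.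

Still open, as far as these compounds go, is how other groups on the benzyl ring, such as bromo, methoxy or trifluoromethyl, would behave at these two places. Also open, from the compounds shown here alone, is whether the reversal would persist with a longer chain in place of the benzyl link.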